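The source may hold more compounds than are shown below. What is called first, only, known or untested is meant among the compounds shown, and "the series" means these compounds.

Compound 1 `N#Cc1ccccc1CN1CCc2c(sc(NC(=O)c3ccccc3Cl)c2C(N)=O)C1`: > 50000 nM
Compound 2 `NC(=O)c1c(NC(=O)c2ccccc2Cl)sc2c1CCN(Cc1ccccc1Cl)C2`: 27500 nM

In a functional assay on HeLa cells (Homo sapiens) for antiproliferative activity, with a stated time of 24 h (a lower number here means a stronger inhibitor, a higher number a weaker inhibitor), compound 1 gives only a limit, > 50000 nM, so its exact number is not known (the limit of > 50000 nM in this assay, at which 1 of the 2 values shown sits). Compound 3 `NC(=O)c1c(NC(=O)c2ccccc2Cl)sc2c1CCN(Cc1ccc([N+](=O)[O-])cc1)C2` differs from compound 1 by 4-nitrophenyl in place of 2-cyanophenyl on a saturated chain carbon bound to an amine nitrogen in a ring. Among the measured compounds shown here, the one measured step that also swaps this group, an at least 1.8-fold lower number from compound 1 to compound 2 (0.25 log units; that floor lies within the scatter), sits at the floor of the scatter and gives little guidance. The expected step is an at least 1.2-fold lower number from compound 1 to compound 3 (0.09 log units; that floor lies within the scatter), nothing beyond the scatter, so compound 3 is estimated at 40000 nM, in a range from 12000 nM to 120000 nM, with a real chance that only a limit is reported.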

Compound 3, half-maximal inhibitory concentration: 46100 nM
Compound 3: middle estimate off by 1.2-fold (0.06 log units), on the low side; the range from low to high includes it.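

In this assay, 4-nitrophenyl in place of 2-chlorophenyl gives a 1.7-fold higher number from compound 2 to compound 3 (0.22 log units; within the scatter), so a group with different atoms at this position leaves the number where repeated measurements could also place it. The other step, an at least 1.0-fold lower number from compound 1 to compound 3 (0.03 log units; that floor lies within the scatter), has only a floor, so it cannot separate 4-nitrophenyl from 2-cyanophenyl: the limit of > 50000 nM in this assay, at which 1 of the 3 values shown sits. Still open, from the compounds shown here alone, is whether an amine or a carboxylic acid on this aromatic ring, or a longer chain leading to the ring, would move the number beyond the scatter.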